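Triazine anilides: aryloxy to methoxyethoxy swap on the aniline

The source may report more compounds than this note shows. Statements on the series, on what has been measured and on what is new or still open speak of the compounds shown alone.

Measured so far:
compound 1, `C=CC(=O)Nc1cccc(Nc2ncnc(Nc3ccc(Oc4ccc(OC)cc4)cc3)n2)c1`, > 100000 nM
compound 2, `C=CC(=O)Nc1cccc(Nc2nc(N)nc(Nc3ccc(OCCOC)cc3)n2)c1`, 18900 nM

Compound 1 carries a 4-methoxyphenoxy group on the aniline ring. In a functional assay on Ramos cells (Homo sapiens) for antiproliferative activity, read by CCK-8 assay, with a stated time of 24 h (a higher number here means a weaker inhibitor, a lower number a stronger inhibitor), compound 1 gives > 100000 nM, and this is a limit of the assay, not a number; it is the only limit among the two values, as the limit of > 100000 nM in this assay, at which 1 of the 2 values shown sits, shows. Compound 2 carries a 2-methoxyethoxy group instead, and an additional amino group on the shared core; in this assay compound 2 gives 18900 nM, a measured number. For the measured compounds named here, no step between compound 1 and compound 2 is counted, since they differ in two places.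

Compound 3, `C=CC(=O)Nc1cccc(Nc2ncnc(Nc3ccc(OCCOC)cc3)n2)c1`, is not yet measured. It differs from compound 1 in one place: 2-methoxyethyl in place of 4-methoxyphenyl on an oxygen on an aromatic ring. Going by the values given here, the only measured compound with the 2-methoxyethoxy group is compound 2, whose value in this assay is a number rather than a limit.

Compound 3 is expected to give 40000 nM in this assay, with a likely range from 10000 nM to 150000 nM, an estimated step of an at least 2.5-fold lower number from compound 1 to compound 3 (0.39 log units; beyond the scatter) towards stronger inhibition, though a limit remains possible.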

Compound 3, half-maximal inhibitory concentration: 181000 nM
Compound 3: middle estimate off by 4.5-fold (0.66 log units), on the low side; the measured number lies above the stated range.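

For the compounds shown here, compound 2 and compound 3 differ in one place only, and this pair gives the first readable step: in this assay, hydrogen in place of amino on an aromatic carbon gives a 9.6-fold higher number from compound 2 to compound 3 (0.98 log units; beyond the scatter). With the 2-methoxyethoxy group held constant, the number of compound 2 is therefore not carried by that group alone, since compound 3, which lacks the amino group, gives 181000 nM. Compound 1 gives > 100000 nM, which is a limit and not a number, so the step for 4-methoxyphenoxy to 2-methoxyethoxy cannot be read: the limit of > 100000 nM in this assay, at which 1 of the 3 values shown sits.

Whether the step between hydrogen and amino holds with the 4-methoxyphenoxy group in place remains open, as the only compound shown with that group carries hydrogen and sits at a limit. Also open, from the compounds shown here alone, is how a methylamino or dimethylamino group in place of the amino group on the shared core, or a longer chain in place of 2-methoxyethyl, would read in this assay.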